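Swapping Dichlorobenzyl for Methoxybenzyl on a Shared Core

The source may report more compounds than this note shows. Statements on the series, on what has been measured and on what is new or still open speak of the compounds shown alone.

Of the compounds shown here, three built on one shared core have been tested in a functional assay on KM12 cells (Homo sapiens) for inhibition, read by sulforhodamine B assay, with a stated time of 48 h; on this read-out lower numbers stand for higher toxicity in this test and higher numbers for lower toxicity in this test. Compound 1, `CCOC(=O)[C@H](CCC(=O)O)NC(=O)c1ccc(CNc2nc3cc(N)cc(N)c3nc2-c2ccccc2)cc1`, gives in this assay only a limit of the test, < 100000 nM. Compound 3, `CCOC(=O)[C@H](CCC(=O)O)NC(=O)c1ccc(Oc2nc3cc(N)cc(N)c3nc2-c2ccccc2)cc1`, likewise returns only a limit in this assay, < 100000 nM. Compound 2, `Nc1cc(N)c2nc(-c3ccccc3)c(NCc3ccc(Cl)c(Cl)c3)nc2c1`, the starting point of the step followed here, also reaches no more than a limit in this assay, < 100000 nM. Compound 2 therefore cannot be ranked against compound 1 or compound 3: the limit of < 100000 nM in this assay, at which 3 of the 3 values shown sit.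

Compound 4, `COc1ccc(CNc2nc3cc(N)cc(N)c3nc2-c2ccccc2)cc1`, differs from compound 2 by 4-methoxyphenyl in place of 3,4-dichlorophenyl on a saturated chain carbon bound to a nitrogen on an aromatic ring. Within the data shown here, no measured pair isolates this change, and nothing among the three results separates one compound from another. The step from compound 2 to compound 4 in this assay is therefore expected to be modest, a step that the limit leaves unreadable from compound 2 to compound 4, with no direction that would stand out beyond the scatter. For compound 4 the expected result in this assay is 30000 nM, with a range from 3000 nM to 100000 nM, and a real chance that the test once more reports only a limit.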

Compound 4, concentration lethal to 50% of the cells: < 100000 nM
Compound 4 ended at the assay's limit (the forecaster's own chance of this, stated with the estimate: 60%); the middle value lies beyond the limit too.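

With compound 2 and compound 4 both reporting only a limit in this assay, no step can be read between them: the limit of < 100000 nM in this assay, at which 4 of the 4 values shown sit.

The compounds shown leave open what value lies behind each limit, and whether 4-methoxyphenyl and 3,4-dichlorophenyl differ at all in this assay.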